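Shortening the ether chain while adding a carboxylic acid

The compounds below may be only part of what the source reports. "The series", "measured", "known", "first", "only" and "open" are said of these compounds alone.

Compound 1 `CCOC(=O)CCCCOc1ccc2c(=O)c(-c3ccc(O)cc3)coc2c1` gives 240 nM in an assay (Cricetulus griseus) for inhibition of aldehyde dehydrogenase, mitochondrial (Homo sapiens) (on this read-out lower numbers stand for stronger inhibition and higher numbers for weaker inhibition), the highest of the two numbers in hand. Compound 3 `CCOc1ccc2c(=O)c(-c3ccc(O)cc3)coc2c1` reaches 80 nM in this assay, and a 3.0-fold lower number from compound 1 to compound 3 (0.48 log units; beyond the scatter) lies beyond the scatter. Compound 2 `O=C(O)COc1ccc(-c2coc3cc(OCC(=O)O)ccc3c2=O)cc1` yields only a limit, >> 9000 nM in this assay. The unmeasured compound 4 `CC(Oc1ccc2c(=O)c(-c3ccc(O)cc3)coc2c1)C(=O)O` differs from compound 1 by 1-carboxyethyl in place of 4-(ethoxycarbonyl)butyl on an oxygen on an aromatic ring. Among the compounds with values here, the one measured step that bears on it, the loss of the ester chain, was modest and favourable; yet compound 4 keeps a short chain and brings in a carboxylic acid, a feature also found in compound 2, which gave only a limit (the limit of >> 9000 nM in this assay, at which 1 of the 3 values shown sits). The expected step is therefore towards weaker binding, a 2.5-fold higher number from compound 1 to compound 4 (0.40 log units; beyond the scatter), and compound 4 is estimated at 600 nM with a range from 150 nM to 3000 nM.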

Compound 4, half-maximal inhibitory concentration: 2500 nM
Compound 4: middle estimate off by 4.2-fold (0.62 log units), on the low side; measured number inside the range.
By their numbers in this assay, from the lowest: compound 3; then compound 1; then compound 4. At a limit, above all of these: compound 2.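

Carboxy in place of hydrogen on a saturated chain carbon bound to an oxygen on an aromatic ring gives a 31-fold higher number from compound 3 to compound 4 (1.49 log units; beyond the scatter), so in this assay a short chain does not by itself keep the stronger inhibition of compound 3. Replacing the whole ester chain gives a 10-fold higher number from compound 1 to compound 4 (1.02 log units; beyond the scatter), so compound 4 also falls behind the longer ester. Compound 2 also carries a carboxylic acid and stands at a limit: the limit of >> 9000 nM in this assay, at which 1 of the 4 values shown sits.

As far as these compounds go, it remains open whether the loss follows from the carboxylic acid or from its place on the chain. A carboxylic acid at the end of a longer chain, or a primary amide on the short chain, would separate the two.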